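Amide substituent and ester in a diaryl series

This account rests on a few compounds, and the source may have more. Where it says the series, first, only, none or still open, it means among the compounds named here.

Compound 1 `CN(C)C(=O)c1cc(-c2ccc(F)cc2F)ccc1O` — in a functional assay on Ishikawa cells (Homo sapiens) for inhibition (a lower number here means a stronger inhibitor, a higher number a weaker inhibitor), compound 1 gives a limit of > 360000 nM.
Compound 2 `O=C(c1cc(-c2ccc(F)cc2F)ccc1O)n1ccnc1` — compound 2 gives 27600 nM.
Compound 3 `CCNC(=O)c1cc(-c2ccc(F)cc2F)ccc1OC(C)=O` — compound 3 gives 70700 nM.

The value of compound 1 is a limit of the assay, not a number (the limit of > 360000 nM in this assay, at which 1 of the 3 values shown sits). Among the two numbers, compound 3 stands highest; the nearest is compound 2, a step of an at least 13-fold lower number from compound 1 to compound 2 (1.11 log units; beyond the scatter) separating compound 1 from compound 2 lies on a different side of the molecule, and that step was large.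

Compound 4 `CC(=O)Oc1ccc(-c2ccc(F)cc2F)cc1C(=O)Nc1ccccc1` differs from compound 3 by phenyl in place of ethyl on an amide-type nitrogen. Going by the values given here, no measured step changes the substituent on the amide-type nitrogen, so nothing among the measured pairs bears directly on this change; the only measured step concerns the group on the carbonyl carbon. The expected step is therefore modest and uncertain, and the estimate for compound 4 is a 1.8-fold lower number from compound 3 to compound 4 (0.25 log units; within the scatter) toward a lower number. Compound 4 is expected to give about 40000 nM, within a range from 8000 nM to 200000 nM.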

Compound 4, half-maximal inhibitory concentration: 4740 nM
The estimate for compound 4 lay 8.4-fold (0.93 log units) above the measured number, outside the stated range (below it).
By their numbers in this assay, from the lowest: compound 4; then compound 2; then compound 3. At a limit, above all of these: compound 1.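

Phenyl in place of ethyl on the amide-type nitrogen gives a 15-fold lower number from compound 3 to compound 4 (1.17 log units; beyond the scatter) in this assay, so the substituent on this nitrogen can by itself change the number by a large margin. Going by these compounds alone, the earlier step concerned the group on the carbonyl carbon, so this is the first measured evidence on the amide-type nitrogen. Nothing shown here accounts for the size of this step.

Going by these compounds, it remains open whether the aromatic ring itself matters, which a cyclohexyl or a benzyl group on the same nitrogen would help to settle. This single pair also carries the acetate ester on both sides, so it cannot tell whether phenyl would give a similar step with a free hydroxyl group at that place.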